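This account rests on a few compounds, and the source may have more. Where it says the series, first, only, none or still open, it means among the compounds named here.

In a functional assay on the whole organism (strain Swiss) with Mus musculus as the target, in the maximal electroshock model, with a stated time of 0.5 h, at a dose of 300 mg/kg by the intraperitoneal route (on this read-out lower numbers stand for a weaker effect and higher numbers for a stronger effect at the one dose given), compound 1 `CCC(C(=O)N1CCN(c2cccc(Cl)c2)CC1)N1C(=O)CCC1=O` gives 50%, the second highest of three numbers. Compound 2 `CCC(C(=O)N1CCN(c2ccccc2F)CC1)N1C(=O)CCC1=O` gives 100%, and compound 3 `CCC(C(=O)N1CCN(c2ccc(C(F)(F)F)cc2)CC1)N1C(=O)CCC1=O` gives 0%. For the measured compounds named here, the one measured step that changes a single place, a number 50 percentage points higher from compound 1 to compound 2 (beyond the scatter), concerns the group on the amine nitrogen in a ring, not the chain. Compound 4 `CC(C(=O)N1CCN(c2cccc(Cl)c2)CC1)N1C(=O)CCC1=O` differs from compound 1 elsewhere: hydrogen in place of methyl on a saturated chain carbon, two bonds along the chain from an amide-type nitrogen in a ring and a carbonyl carbon. Going by the values given here, no measured step touches that chain, so the data give no size for a move when ethyl becomes methyl. The expectation therefore rests on compound 1 alone, and the step of a number 10 percentage points lower from compound 1 to compound 4 (within the scatter) is expected to stay within the scatter. Compound 4 is estimated at 40%, within a range from 10% to 80%.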

Compound 4, a percentage reported as activity, at one dose (the size of the read-out at that dose, not a potency): 100%
The estimate for compound 4 lay 60 percentage points below the measured number; the measured number lies above the stated range.
By their numbers in this assay, from the lowest: compound 3; then compound 1; then compounds 2 and 4 (each within the scatter of the next).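

In this assay, the saturated chain carbon proves to be a sensitive position: ethyl to methyl, a loss of one carbon, gives a number 50 percentage points higher from compound 1 to compound 4 (beyond the scatter) with the rest of the molecule unchanged. This step matches in size a number 50 percentage points higher from compound 1 to compound 2 (beyond the scatter) at the group on the amine nitrogen in a ring, so the chain matters as much here as that group. No measured evidence explains the effect of this change.

On these data alone, whether a longer chain such as propyl, or an amine at that carbon, would raise or lower the number remains open. Also open, as far as these compounds go, is whether ethyl to methyl gives a similar step with other groups on the amine nitrogen in a ring.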